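A Chloro Substituent on a Thioether Semicarbazone

The source may report more compounds than this note shows. Statements on the series, on what has been measured and on what is new or still open speak of the compounds shown alone.

Compound 1, `CCC(C)c1ccc(Oc2ccc(/C=N\NC(N)=O)cc2)cc1`: 86.9 mg/kg
Compound 2, `C/C(=N/NC(N)=O)c1ccc(Oc2ccc(C)cc2)cc1`: 18.7 mg/kg
Compound 3, `NC(=O)N/N=C/c1ccc(Sc2ccccc2)cc1`: > 46 mg/kg

Of the compounds shown here, three have been tested in a functional assay on the whole organism with Mus musculus as the target, with a stated time of 1 h; a lower number here means that less compound is needed, a higher number that more compound is needed for the effect. Compound 1 gives 86.9 mg/kg in this assay and compound 2 gives 18.7 mg/kg. Compound 3 stands apart, as for it the assay reports only a limit, > 46 mg/kg, which is not a number but the edge of what could be measured; it is the limit of > 46 mg/kg in this assay, at which 1 of the 3 values shown sits. Where compound 3 truly stands is therefore open.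

Compound 4, `NC(=O)N/N=C/c1ccc(Sc2ccc(Cl)cc2)cc1`, differs from compound 3 in one place: chloro in place of hydrogen on an aromatic carbon. Going by the values given here, no step between two measured compounds is available to show what such a change does here, so the expectation rests on compound 3 alone. The step from compound 3 to compound 4 is expected to be small, with no clear direction beyond the usual scatter, giving a step that the limit leaves unreadable from compound 3 to compound 4. Compound 4 is therefore estimated at 60 mg/kg, within a range from 25 mg/kg to 150 mg/kg, and there is a real chance that only a limit is reported again.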

Compound 4, dose for half-maximal effect: > 120 mg/kg
Compound 4 gave a limit, no number; the forecaster's own chance of this, stated with the estimate: 50%; at least 2.0-fold (0.30 log units) between middle value and limit.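

Going by these compounds alone, compound 3 and compound 4 are both reported in this assay only as limits, not as numbers, so no step between them can be read. From the compounds shown here alone, what chloro in place of hydrogen does to the dose needed, and where either compound truly stands, remains open.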